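Acetoxymethyl on the carbonyl of compound 3

A few compounds are considered here, and "the series" means these few. Any claim that something is new, unique, unknown or untested is made for them only; others in the source may bear on it.

In a functional assay on HCT-15 cells (Homo sapiens) (a lower number here means that less compound is needed, a higher number that more compound is needed for the effect), compound 3 (`COC(=O)N1N=C(c2ccc(N(C)C)cc2)OC1c1cc(OC)c(OC)c(OC)c1`) gives 40 uM, level with compound 2 (`CCOC(=O)C(=O)N1N=C(c2ccc(N(C)C)cc2)OC1c1cc(OC)c(OC)c(OC)c1`) at 45 uM, while compound 1 (`COc1cc(C2OC(c3ccc(N(C)C)cc3)=NN2C(C)=O)cc(OC)c1OC`) gives 0.033 uM. Compound 4 (`COc1cc(C2OC(c3ccc(N(C)C)cc3)=NN2C(=O)COC(C)=O)cc(OC)c1OC`) differs from compound 3 by acetoxymethyl in place of methoxy on a carbonyl carbon, with acetoxymethyl in place of methoxy on a carbonyl carbon. Within the data shown here, three measured steps bear on this change. Two are large, a 1200-fold higher number from compound 1 to compound 3 (3.08 log units; beyond the scatter) and a 1400-fold higher number from compound 1 to compound 2 (3.13 log units; beyond the scatter), whereas a 1.1-fold lower number from compound 2 to compound 3 (0.05 log units; within the scatter) stays within the scatter. Among the measured compounds shown here, only methyl has given a low number so far, and no acetoxymethyl compound has been measured, so a partial move towards compound 1 is expected. The expected change is a 40-fold lower number from compound 3 to compound 4 (1.60 log units; beyond the scatter). For compound 4 the estimated value is 1 uM, with an expected range of 0.05 uM to 30 uM.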

Compound 4, concentration for half-maximal effect: 0.019 uM
Compound 4: middle estimate off by 53-fold (1.72 log units), on the high side; the measured number lies below the stated range.
By their numbers in this assay, from the lowest: compounds 4 and 1 (each within the scatter of the next); then compounds 3 and 2 (each within the scatter of the next).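

On the carbonyl carbon bound to the amide-type nitrogen in a ring, acetoxymethyl gives a low number in this assay (a 2100-fold lower number from compound 3 to compound 4 (3.32 log units; beyond the scatter)) (a 2400-fold lower number from compound 2 to compound 4 (3.37 log units; beyond the scatter)), and acetoxy in place of hydrogen on the chain carbon stays within the scatter (a 1.7-fold lower number from compound 1 to compound 4 (0.24 log units; within the scatter)). A low number is therefore no longer tied to methyl alone, while methoxy and ethoxycarbonyl remain the two high compounds. No measured evidence accounts for this split.

Open, as far as these compounds go, is whether hydroxymethyl, aminomethyl or a longer chain on this carbonyl carbon keeps the low number.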